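The source may hold more compounds than are shown below. What is called first, only, known or untested is meant among the compounds shown, and "the series" means these compounds.

In a functional assay on CHO cells for agonist activity at Free fatty acid receptor 1 (Homo sapiens), read by calcium flux (a higher number here means that more compound is needed for the effect, a lower number that less compound is needed), compound 1 `Cc1cccc(-c2cccc(NC(=O)c3nnc(CCC(=O)O)s3)c2)c1` gives 760 nM. Compound 2 `COc1ccc(NC(=O)c2nnc(COc3ccc(CCC(=O)O)cc3)s2)cc1` returns only a limit of this assay, > 10000 nM, namely (the limit of > 10000 nM in this assay, at which 1 of the 3 values shown sits). Compound 3 `O=C(O)CCc1ccc(OCc2nnc(C(=O)Nc3ccc(F)cc3)s2)cc1` gives 6640 nM in this assay, the highest of the two numbers shown, with compound 1 sitting well below it. Among the measured compounds shown here, the one measured step that reaches compound 3, an at least 1.5-fold lower number from compound 2 to compound 3 (0.17 log units; that floor lies within the scatter), puts fluoro in place of methoxy. Compound 4 `O=C(O)CCc1ccc(OCc2nnc(C(=O)Nc3cccc(F)c3)s2)cc1` differs from compound 3 by 3-fluorophenyl in place of 4-fluorophenyl on an amide-type nitrogen. For the measured compounds named here, no measured step moves the fluorine around its ring, so there is nothing to support a shift beyond the scatter in this assay. Compound 4 is therefore expected to give about 5500 nM, plausibly between 2000 nM and 15000 nM, a step of a 1.2-fold lower number from compound 3 to compound 4 (0.08 log units; within the scatter) that stays within the usual scatter.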

Compound 4, half-maximal effective concentration: 1190 nM
Beside the measured number, compound 4's estimate is 4.6-fold (0.66 log units) above it, outside the stated range (below it).
By their numbers in this assay, from the lowest: compounds 1 and 4 (each within the scatter of the next); then compound 3. At a limit, above all of these: compound 2.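

In this assay, the place on the amide-type nitrogen turns out to respond to where the fluorine sits, not only to which group is present: 3-fluorophenyl in place of 4-fluorophenyl gives a 5.6-fold lower number from compound 3 to compound 4 (0.75 log units; beyond the scatter). With 3-fluorophenyl in place of 4-methoxyphenyl, the change is an at least 8.4-fold lower number from compound 2 to compound 4 (0.92 log units; beyond the scatter). Compound 2 stands only at a limit, so that step is a floor: the limit of > 10000 nM in this assay, at which 1 of the 4 values shown sits.

As far as these compounds go, whether 2-fluorophenyl or 3-chlorophenyl on the same nitrogen would match 3-fluorophenyl remains open. So does whether 3-methoxyphenyl would differ from 4-methoxyphenyl in the same direction.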